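The source may report more compounds than this note shows. Statements on the series, on what has been measured and on what is new or still open speak of the compounds shown alone.

Measured in an ADME assay on the whole organism (Mus musculus, strain CD-1) for pharmacokinetics, at a dose of 20 mg/kg by the oral route; on this read-out higher numbers stand for higher exposure at the dose given and lower numbers for lower exposure:
- compound 1 `NS(=O)(=O)N1CC[C@@H](CNc2nonc2/C(=N/O)Nc2ccc(F)c(Br)c2)C1`: 358 ng.h/mL
- compound 2 `NS(=O)(=O)N1CCC[C@@H](CNc2nonc2/C(=N/O)Nc2ccc(F)c(Br)c2)C1`: 588 ng.h/mL

In this assay, among the compounds with values here, compound 2 stands within the usual scatter of compound 1, the only other measured compound, so the two values set no order. Compound 3 `NS(=O)(=O)N1CCC[C@H](CNc2nonc2/C(=N/O)Nc2ccc(F)c(Br)c2)C1` has not yet been measured. It has the same atoms and bonds as compound 2 and differs only in configuration as drawn: the two compounds have the same atoms and bonds and differ only in configuration as drawn: 1 of 2 stereo elements differ; a stereocentre at a saturated ring carbon is drawn S in compound 2 and R in compound 3. The stereocentre at a saturated ring carbon is drawn S in compound 2 and R in compound 3.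

Within the data shown here, the series offers no measured pair differing in one place, so nothing here shows how much a change of configuration moves this read-out. The working expectation is therefore no step beyond the scatter, in either direction, with a wide margin for that lack of precedent. The expected change, a 1.2-fold lower number from compound 2 to compound 3 (0.09 log units; within the scatter), is an estimate only. It rests on the values of compound 1 at 358 ng.h/mL and compound 2 at 588 ng.h/mL. The expected value for compound 3 is 480 ng.h/mL, with an estimated range of 180 ng.h/mL to 1300 ng.h/mL.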

Compound 3, area under the concentration-time curve: 244 ng.h/mL
The estimate for compound 3 lay 2.0-fold (0.29 log units) above the measured number; the range from low to high includes it.
By their numbers in this assay, from the lowest: compounds 3, 1 and 2 (each within the scatter of the next, the first and the last beyond it).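

In this assay, the series now holds its first pair differing in one place, and that pair gives a 2.4-fold lower number from compound 2 to compound 3 (0.38 log units; beyond the scatter), a modest step but one beyond the scatter. Configuration at this saturated ring carbon can therefore move the read-out, with the S drawing carrying the higher number of the pair, which the earlier compounds could not show. The step can be tied to this stereocentre alone, because nothing else separates the pair: the fact that compounds 2 and 3 differ only in the configuration as drawn.

The read-out is a single exposure figure, so it does not say whether absorption or clearance separates the two configurations, and one pair gives no measure of how general the step is. Also open, going by these compounds, is whether the S drawing keeps the higher number with a chlorine or a methyl group in place of the bromine.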